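Swapping 3,5-dichlorophenyl for quinolin-2-yl on the amide

A few compounds are considered here, and "the series" means these few. Any claim that something is new, unique, unknown or untested is made for them only; others in the source may bear on it.

In a functional assay on SK-BR-3 cells (Homo sapiens) for antiproliferative activity, read by MTT assay, with a stated time of 72 h (on this read-out lower numbers stand for stronger inhibition and higher numbers for weaker inhibition), compound 1 `CCN1CCN(c2cc(C)c3cc(NC(=O)c4ccccc4)ccc3n2)CC1` gives 18400 nM and compound 2 `CCN1CCN(c2cc(C)c3cc(NC(=O)c4cc(Cl)cc(Cl)c4)ccc3n2)CC1` gives 2660 nM as the lower of the two numbers. Compound 3 `CCN1CCN(c2cc(C)c3cc(NC(=O)c4ccc5ccccc5n4)ccc3n2)CC1` carries quinolin-2-yl in place of 3,5-dichlorophenyl on a carbonyl carbon. Among the compounds with values here, only one measured step bears on this (a 6.9-fold lower number from compound 1 to compound 2 (0.84 log units; beyond the scatter)), and it brought in the 3,5-dichlorophenyl that now leaves. That step was modest but beyond the scatter. In this assay a modest move toward a higher number is therefore expected (a 2.3-fold higher number from compound 2 to compound 3 (0.35 log units; beyond the scatter)) with this swap. For compound 3 the estimate is 6000 nM with an expected range from 1800 nM to 18000 nM overall.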

Compound 3, half-maximal inhibitory concentration: 3760 nM
Estimate against measurement, compound 3: 1.6-fold (0.20 log units) above; measured number inside the range.
By their numbers in this assay, from the lowest: compounds 2 and 3 (each within the scatter of the next); then compound 1.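

On the carbonyl carbon, quinolin-2-yl and 3,5-dichlorophenyl cannot be told apart in this assay, with a 1.4-fold higher number from compound 2 to compound 3 (0.15 log units; within the scatter). Quinolin-2-yl also improves on plain phenyl, with a 4.9-fold lower number from compound 1 to compound 3 (0.69 log units; beyond the scatter), so at this place a gain over phenyl does not require chlorine atoms. No measured evidence here explains why these two different groups give matching results.

Going by these compounds, it remains open whether a single-ring pyridin-2-yl would match them on the same carbonyl carbon. On these data alone, it is equally open whether a methoxy group or an amine on the phenyl ring would do so.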